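The source may hold more compounds than are shown below. What is called first, only, known or untested is meant among the compounds shown, and "the series" means these compounds.

The series shares a core in which an amide links a propanamide bearing a methanesulfonamide-substituted fluorophenyl to a benzylamine carrying a trifluoromethyl group and a saturated nitrogen ring. Compound 1 `CC(C(=O)NCc1ccc(C(F)(F)F)cc1N1CCCCCCC1)c1ccc(NS(C)(=O)=O)c(F)c1` carries the eight-membered ring and gives 2.8 nM in an assay on CHO cells for antagonist activity at transient receptor potential cation channel subfamily V member 1 (Homo sapiens), read by FLIPR; a lower number here means a stronger inhibitor, a higher number a weaker inhibitor. Compound 2 `CC1CCN(c2cc(C(F)(F)F)ccc2CNC(=O)C(C)c2ccc(NS(C)(=O)=O)c(F)c2)CC1` carries the six-membered ring with a methyl group; in this assay compound 2 gives 0.9 nM, the lowest of the two numbers, and the step of a 3.1-fold lower number from compound 1 to compound 2 (0.49 log units; beyond the scatter) lies beyond the scatter. Compound 3 `CC(C(=O)NCc1ccc(C(F)(F)F)cc1N1CCC(Cc2ccc(F)cc2)CC1)c1ccc(NS(C)(=O)=O)c(F)c1` differs from compound 2 by 4-fluorophenyl in place of hydrogen on a saturated chain carbon bound to a saturated ring carbon. No measured step touches this position; the only step shown concerns the ring itself, so its size offers no direct guide. Compound 3 is therefore expected to stay near compound 2, with the step of a 2.2-fold higher number from compound 2 to compound 3 (0.35 log units; beyond the scatter) estimated as small. Compound 3 is estimated at 2 nM, within the range 0.5 nM to 8 nM.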

Compound 3, inhibition constant: 0.4 nM
Compound 3: middle estimate off by 5.0-fold (0.70 log units), on the high side, and the stated range ends above it.
By their numbers in this assay, from the lowest: compound 3; then compound 2; then compound 1.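

At this position, on a saturated chain carbon bound to a saturated ring carbon, the change from methyl to 4-fluorobenzyl adds 7 heavy atoms and still improves the result in this assay, with a 2.3-fold lower number from compound 2 to compound 3 (0.35 log units; beyond the scatter). Within the data shown here, the earlier compounds showed only a change of the nitrogen ring itself, so this is the first sign that the methyl of compound 2 can be extended with an aromatic ring without loss of inhibition. Nothing available explains this modest gain.

The compounds shown leave open whether the fluorine contributes, which a plain benzyl group would test, and how a longer chain ending in 4-fluorophenyl, an amine or a carboxylic acid would read at this position. They also leave open whether the same group would give a similar step on the eight-membered ring of compound 1.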